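A small swap on the urea phenyl ring of compound 3

The compounds below may be only part of what the source reports. "The series", "measured", "known", "first", "only" and "open" are said of these compounds alone.

Of the compounds shown here, three share one core and have been tested in a functional assay on SR cells (Homo sapiens) for inhibition, read by sulforhodamine B assay, with a stated time of 48 h; on this read-out lower numbers stand for stronger inhibition of growth and higher numbers for weaker inhibition of growth. Compound 1 `COc1cc(-c2nn(-c3cccc(NC(=O)c4cccc(C(F)(F)F)c4)c3)cc2-c2ccncc2)ccc1Cl` gives 4590 nM. Compound 2 `COc1cc(-c2nn(-c3cccc(NC(=O)Nc4ccc(Cl)c(Cl)c4)c3)cc2-c2ccncc2)ccc1Cl` gives 2800 nM. Compound 3 `O=C(Nc1cccc(-n2cc(-c3ccncc3)c(-c3ccc(Cl)c(O)c3)n2)c1)Nc1ccc(Cl)c(Cl)c1` gives 15000 nM, the highest number of the three and thus the weakest inhibition of growth in this set. Compound 4 `O=C(Nc1cccc(-n2cc(-c3ccncc3)c(-c3ccc(Cl)c(O)c3)n2)c1)Nc1ccc(Cl)c(C(F)(F)F)c1` is the next compound; it differs from compound 3 by trifluoromethyl in place of chloro on an aromatic carbon.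

Two measured steps exist. The step of a 5.4-fold higher number from compound 2 to compound 3 (0.73 log units; beyond the scatter) touches a different part of the molecule and does not speak to this change. The step of a 1.6-fold lower number from compound 1 to compound 2 (0.21 log units; within the scatter) exchanges, among other things, a trifluoromethyl-bearing ring for a dichloro-bearing ring and stays within the scatter, which suggests that trading chloro for trifluoromethyl on this ring changes little. For compound 4 the expected step in this assay is therefore a 1.2-fold lower number from compound 3 to compound 4 (0.06 log units; within the scatter), that is, no change beyond the scatter. The estimate for compound 4 is 13000 nM, with a range from 5000 nM to 35000 nM.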

Compound 4, concentration for total growth inhibition: 2520 nM
For compound 4 the middle estimate is 5.2-fold (0.71 log units) above the measured one, and the stated range ends above it.
By their numbers in this assay, from the lowest: compounds 4, 2 and 1 (each within the scatter of the next); then compound 3.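

In this assay, replacing chloro with trifluoromethyl on this aromatic carbon, which turns the 3,4-dichlorophenyl into a 4-chloro-3-(trifluoromethyl)phenyl, gives a 6.0-fold lower number from compound 3 to compound 4 (0.77 log units; beyond the scatter), so the group at this position does matter for growth inhibition in this series. The earlier step between compound 1 and compound 2 could not show this, as it also changed what joins the ring to the carbonyl carbon, whereas compound 3 and compound 4 differ in this one place only. Nothing measured here explains why the number falls.

The compounds shown leave open whether a methyl or a nitrile at this position would give a similar number. They also leave open whether the same swap would have a similar effect on compound 2, where the oxygen carries a methyl.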